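Ring size swap on a quaternary ammonium tail

This account rests on a few compounds, and the source may have more. Where it says the series, first, only, none or still open, it means among the compounds named here.

Measured so far:
compound 1 `Cc1cc(OCCCCCCC[N+]23CCN(CC2)CC3)ccc1-n1cc(C(=O)Nc2cc(F)cc(F)c2)c(=O)c2ccc(N(C)C)nc21` gives "not active" (no number reported)
compound 2 `Cc1cc(OCCCCCCC[N+]2(C)CCCCC2)cc(-n2cc(C(=O)Nc3cc(F)cc(F)c3)c(=O)c3ccc(N(C)C)nc32)c1` gives 46.8%

Going by the values given here, in an assay on LX2 cells for inhibition of COL1A1 promoter (Homo sapiens), read by a luciferase reporter, with a stated time of 24 h, tested at 20 uM (on this read-out lower numbers stand for a weaker effect and higher numbers for a stronger effect at the one concentration tested), compound 2 gives 46.8%, the only number in this set; compound 1 is reported as "not active" (no number reported) with no number. Compound 3 `CC[N+]1(CCCCCCCOc2cc(C)cc(-n3cc(C(=O)Nc4cc(F)cc(F)c4)c(=O)c4ccc(N(C)C)nc43)c2)CCCC1` differs from compound 2 only at the tail end: a group of 7 heavy atoms (6 carbon, 1 nitrogen; one five-membered non-aromatic ring with 1 hetero atom) in place of a group of 7 heavy atoms (6 carbon, 1 nitrogen; one six-membered non-aromatic ring with 1 hetero atom), on a saturated chain carbon, seven bonds along the chain from an oxygen on an aromatic ring. The atoms are the same and only the ring size changes. Among the compounds with values here, with no measured pair to show what such a change does, the step of a number 1.8 percentage points lower from compound 2 to compound 3 (within the scatter) is expected to stay within the usual scatter. Compound 3 is estimated at 45%, between 25% and 65%.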

Compound 3, a percentage reported as inhibition, at one concentration (the size of the read-out at that concentration, not a potency): 35.1%
Compound 3: the middle estimate sits 9.9 percentage points above what was measured, and the stated range covers the measured number.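

With the same atoms and the same net charge of +1 at the tail end, placing the five-membered ring where the six-membered ring stood gives a number 11.7 percentage points lower from compound 2 to compound 3 (beyond the scatter) and so shows that this position responds to how the atoms are joined, not only to which atoms are present. Going by these compounds alone, this is the first measured step at this tail end, and it is modest. Nothing shown explains why the number moves. Going by these compounds, whether a seven-membered ring, a tertiary amine or a carboxylic acid at the tail end would keep the effect remains open.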